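The source may report more compounds than this note shows. Statements on the series, on what has been measured and on what is new or still open speak of the compounds shown alone.

In an ADME assay on RAW264.7 cells (Mus musculus) for cytotoxicity, read by neutral red uptake, with a stated time of 24 h (a lower number here means that less compound is tolerated, a higher number that more compound is tolerated), compound 1 `CC(C(=O)NOCc1ccccc1)N1C(=O)S/C(=C\c2ccccc2)C1=O` gives > 128000 nM, which is a limit of the assay and not a number. Compound 2 `CCCC/C=C1\SC(=O)N(CC(=O)NOCc2ccccc2)C1=O` gives > 128000 nM, also only a limit, so it stands with the limit of > 128000 nM in this assay, at which 2 of the 2 values shown sit. Compound 3 `CCCC/C=C1\SC(=O)N(C(C)C(=O)NOCc2ccccc2)C1=O` is reached from compound 2 through (methyl in place of hydrogen on a saturated chain carbon bound to an amide-type nitrogen in a ring and a carbonyl carbon), with methyl in place of hydrogen on the saturated chain carbon. Within the data shown here, no measured step yet shows what such a change does. The expected a number no higher from compound 2 to compound 3 (the limit leaves the size open) is none beyond the scatter in this assay. Compound 3 is estimated at 128000 nM, with an expected range from 60000 nM to 256000 nM.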

Compound 3, half-maximal cytotoxic concentration: 43900 nM
The estimate for compound 3 lay 2.9-fold (0.46 log units) above the measured number; measured number outside the range, below it.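

In this assay, methyl in place of hydrogen on the saturated chain carbon gives an at least 2.9-fold lower number from compound 2 to compound 3 (0.46 log units; beyond the scatter), so this position can affect how much compound the cells tolerate. With that methyl kept, butyl in place of phenyl on the double-bonded chain carbon gives an at least 2.9-fold lower number from compound 1 to compound 3 (0.46 log units; beyond the scatter), so the effect of the methyl depends on the group at that other place. Both steps start from a limit of the assay, so their full size stays open: the limit of > 128000 nM in this assay, at which 2 of the 3 values shown sit.

From the compounds shown here alone, whether an ethyl, a longer chain or an amine on the saturated chain carbon would lower the number further remains open.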